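Toxicity of a Methoxy Analogue Predicted From Two Measurements

This account rests on a few compounds, and the source may have more. Where it says the series, first, only, none or still open, it means among the compounds named here.

Two compounds share one core and differ only in the short chain attached to a nitrogen on an aromatic ring. Compound 1 `CC(O)CN(c1ccnc(Nc2ccc(C#N)cc2)n1)c1c(F)cc(-c2ccc(C#N)cc2)cc1F` gives 9800 nM in an ADME assay on MT4 cells (Homo sapiens) for cytotoxicity, read by MTT assay, with a stated time of 5 days; on this read-out lower numbers stand for higher toxicity in this test and higher numbers for lower toxicity in this test. Within the data shown here, compound 2 `N#Cc1ccc(Nc2nccc(N(CCCF)c3c(F)cc(-c4ccc(C#N)cc4)cc3F)n2)cc1` gives 241000 nM and so holds the highest of the two numbers, meaning the lowest toxicity measured here; the single known step is a 25-fold higher number from compound 1 to compound 2 (1.39 log units; beyond the scatter). Compound 3 `COCN(c1ccnc(Nc2ccc(C#N)cc2)n1)c1c(F)cc(-c2ccc(C#N)cc2)cc1F` has not been tested; it differs from compound 2 by methoxy in place of 2-fluoroethyl on a saturated chain carbon bound to a nitrogen on an aromatic ring. Among the measured compounds shown here, only the step from compound 1 to compound 2 bears on this, and it shows that swapping a small group in this place can move the number by a large amount. Compound 3 is expected to land between the two measured values, a little nearer compound 2, giving an estimated 60000 nM with a range from 10000 nM to 250000 nM. That estimate corresponds to an expected step of a 4.0-fold lower number from compound 2 to compound 3 (0.60 log units; beyond the scatter).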

Compound 3, half-maximal cytotoxic concentration: 238000 nM
For compound 3 the middle estimate is 4.0-fold (0.60 log units) below the measured one, within the range that was stated.
By their numbers in this assay, from the lowest: compound 1; then compounds 3 and 2 (each within the scatter of the next).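

In this assay, methoxy in place of 2-fluoroethyl gives a 1.0-fold lower number from compound 2 to compound 3 (0.01 log units; within the scatter) and so leaves the two compounds indistinguishable, even though the entering group holds an oxygen and a hydrogen-bond acceptor where the leaving group holds a fluorine and no acceptor. Methoxy in place of 1-hydroxyethyl gives a 24-fold higher number from compound 1 to compound 3 (1.39 log units; beyond the scatter) as a large step, so among these three compounds, compound 1 is the one that stands apart, and a swap at this position does not always move the number. No evidence on the cause of this pattern is at hand. 

On these data alone, it remains open whether an amine or a carboxylic acid at this position would give a number like that of compound 1 or like that of compound 3. Whether a longer chain would keep the number of compound 3 is also unresolved.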